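A Chlorinated Ring Replaces a Small Alkene

This account rests on a few compounds, and the source may have more. Where it says the series, first, only, none or still open, it means among the compounds named here.

Three compounds share one core and differ only in the group sitting on a saturated chain carbon bound to an aromatic nitrogen: compound 1 `CCOC(=O)C(=O)CC(=O)/C=C/c1cn(CCC(C)C)c2ccccc12`, compound 2 `C/C=C/Cn1cc(/C=C/C(=O)CC(=O)C(=O)OCC)c2ccccc21` and compound 3 `C=C(C)Cn1cc(/C=C/C(=O)CC(=O)C(=O)OCC)c2ccccc21`. In an assay on isolated protein for inhibition of DNA nucleotidylexotransferase (Homo sapiens), read by scintillation counting, with a stated time of 10 min (a lower number here means a stronger inhibitor, a higher number a weaker inhibitor), compound 1 gives only a limit, > 40 uM. In this assay compound 2 likewise gives a limit, > 40 uM. Compound 3 also gives only a limit in this assay, > 40 uM. Because all three sit at the limit of > 40 uM in this assay, at which 3 of the 3 values shown sit, the steps between them cannot be read: a step that the two limits leave unreadable from compound 1 to compound 2, a step that the two limits leave unreadable from compound 1 to compound 3 and a step that the two limits leave unreadable from compound 2 to compound 3. Compound 3 therefore stands at the limit together with the other two values, with no ranking possible among them.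

Compound 4 `CCOC(=O)C(=O)CC(=O)/C=C/c1cn(Cc2ccc(Cl)cc2)c2ccccc12` differs from compound 3 by 4-chlorophenyl in place of 1-methylethenyl on a saturated chain carbon bound to an aromatic nitrogen. Among the measured compounds shown here, none of the measured steps has a readable size, so none points in a direction for this change, and the expectation can rest only on the change itself and the fact that every value so far is a limit. Compound 4 is expected to land near 30 uM, somewhere within 8 uM to 100 uM. That estimate means an expected step of an at least 1.3-fold lower number from compound 3 to compound 4 (0.12 log units; that floor lies within the scatter), with a real chance that this assay again reports only a limit.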

Compound 4, concentration for 50% inhibition: 40 uM
Compound 4: the middle estimate sits 1.3-fold (0.12 log units) below what was measured, within the range that was stated.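

Among the compounds shown here, with 4-chlorophenyl in place of 1-methylethenyl on a saturated chain carbon bound to an aromatic nitrogen, compound 4 gives a plain number in this assay, 40 uM, the first value here that is not a limit. The change reads as a number no higher from compound 3 to compound 4 (the limit leaves the size open) and the other two changes at that place read as a number no higher from compound 2 to compound 4 (the limit leaves the size open) and as a number no higher from compound 1 to compound 4 (the limit leaves the size open) and none of these steps is readable in size, so the aromatic ring cannot be ranked against the smaller groups: the limit of > 40 uM in this assay, at which 3 of the 4 values shown sit.

The compounds shown leave open whether the chlorine matters, a question that a plain benzyl group on the same nitrogen would address. They also leave open whether a carboxylic acid in place of the ethyl ester would bring a number well clear of this limit.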